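Pyridin-3-yl for 2-methoxyethyl on a carbonyl carbon

The source may hold more compounds than are shown below. What is called first, only, known or untested is meant among the compounds shown, and "the series" means these compounds.

Among the measured compounds shown here, in a physicochemical assay for lipophilicity, using the shake flask method, in phosphate buffer, measured as octanol-water partition, with a stated time of 30 min, at pH 7.4 (a lower number here means a more polar compound, a higher number a more lipophilic compound), compound 1 `COCCC(=O)Nc1cnc(NCc2c(F)ccc3c2CCO3)n2cnnc12` gives 1.4, the lower of the two numbers available so far. Compound 2 `CC(=O)N1CCC(c2cnc(NCc3c(F)ccc4c3CCO4)c3cn[nH]c(=O)c23)CC1` gives 2.9 in this assay, and this gap between the two compounds lies beyond the usual scatter. For the measured compounds named here, the two measured compounds differ in more than one place, so the series offers no measured step to borrow for the next comparison.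

Compound 3 `O=C(Nc1cnc(NCc2c(F)ccc3c2CCO3)n2cnnc12)c1cccnc1` has not yet been measured. It carries pyridin-3-yl in place of 2-methoxyethyl on a carbonyl carbon, relative to compound 1 (pyridin-3-yl in place of 2-methoxyethyl on a carbonyl carbon). The same difference can be read as (2-methoxyethyl)carbonyl to (pyridin-3-yl)carbonyl. A chain with no ring leaves, and one six-membered aromatic ring with 1 hetero atom enters.

Going by the values given here, the expectation starts from compound 1 at 1.4 and rests on this structural change alone, with no measured precedent. An upward move of moderate size is expected in this assay, with the estimated step being a number 0.50 log units higher from compound 1 to compound 3 (beyond the scatter). For compound 3 the estimated value is 1.9, with an expected range from 1.5 to 2.4.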

Compound 3, distribution coefficient: 2
The estimate for compound 3 lay 0.10 log units below the measured number; the range from low to high includes it.
By their numbers in this assay, from the lowest: compound 1; then compound 3; then compound 2.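

In this assay the place on the carbonyl carbon now has its first measured step, and pyridin-3-yl in place of 2-methoxyethyl gives a number 0.60 log units higher from compound 1 to compound 3 (beyond the scatter) with the rest of compound 1 unchanged. Earlier, the two measured compounds differed in more than one place, so their gap could not be assigned to any single group, whereas this step belongs to this one exchange on the shared core. The exchange replaces a chain with no ring by one six-membered aromatic ring and adds heavy atoms, while the counts of hydrogen-bond donors and acceptors stay the same, and nothing measured here gives a reason for the size of the step.

A single exchange cannot separate the contribution of the ring from that of its nitrogen, or from that of the added heavy atoms, and a phenyl ring and a cyclohexyl ring on the same carbonyl carbon would be the direct tests. Also open, as far as these compounds go, is how a basic amine chain or a carboxylic acid at this place would compare with 2-methoxyethyl and pyridin-3-yl.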